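The compounds below may be only part of what the source reports. "The series", "measured", "known", "first", "only" and "open" are said of these compounds alone.

Working notes: compound 2 `Cn1c(=O)c(S(=O)(=O)c2ccc(F)cc2F)cc2cnc(Nc3ccc4sccc4c3)nc21` sits in the middle of the three numbers in a functional assay on K562 cells (Homo sapiens) for inhibition, read by trypan blue exclusion, with a stated time of 72 h; a lower number here means a stronger inhibitor, a higher number a weaker inhibitor. Compound 2 gives 500 nM, compound 3 `Cn1c(=O)c(S(=O)(=O)c2ccc(F)cc2)cc2cnc(Nc3ccc4[nH]ccc4c3)nc21` gives 200 nM, and compound 1 `Cn1c(=O)c(S(=O)(=O)c2ccc(C(=O)O)cc2)cc2cnc(Nc3ccc4[nH]ccc4c3)nc21` gives 5000 nM.

The next compound to read is compound 4 `Cn1ccc2cc(Nc3ncc4cc(S(=O)(=O)c5ccc(F)cc5F)c(=O)n(C)c4n3)ccc21`, with 1-methyl-1H-indol-5-yl in place of 1-benzothiophen-5-yl on a nitrogen on an aromatic ring.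

Among the measured compounds shown here, the only measured single-place step is a 25-fold lower number from compound 1 to compound 3 (1.40 log units; beyond the scatter). It is large, but it is fluoro in place of carboxy on an aromatic carbon, so it does not size a change on that nitrogen. For the measured compounds named here, no measured step isolates that change. Compound 3, at 200 nM, carries the entering group without its methyl, but it also differs from compound 2 elsewhere, which makes it only a weak hint toward a lower number.

No step beyond the scatter is expected in this assay. The estimated step is a 1.7-fold lower number from compound 2 to compound 4 (0.22 log units; within the scatter). For compound 4 the expected value is 300 nM, with an estimated range of 100 nM to 900 nM.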

Compound 4, half-maximal inhibitory concentration: 750 nM
The estimate for compound 4 lay 2.5-fold (0.40 log units) below the measured number; the range from low to high includes it.
By their numbers in this assay, from the lowest: compound 3; then compounds 2 and 4 (each within the scatter of the next); then compound 1.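

In this assay the change from 1-benzothiophen-5-yl to 1-methyl-1H-indol-5-yl on a nitrogen on an aromatic ring gives a 1.5-fold higher number from compound 2 to compound 4 (0.18 log units; within the scatter) and so stays within the scatter. Among the compounds shown here, this is the first step read at this position, and in this pair the two groups cannot be told apart, whereas the only earlier step, at a different place, was large (a 25-fold lower number from compound 1 to compound 3 (1.40 log units; beyond the scatter)). Nothing on hand explains this result.

Open, from the compounds shown here alone, is what the methyl of 1-methyl-1H-indol-5-yl contributes on its own, since one pair cannot separate it from the exchange of the ring hetero atom. Also open, going by these compounds, is whether a different group on that nitrogen, such as a phenyl carrying a piperazine, would move the number beyond the scatter.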